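Swapping the 2-nitrophenyl group of compound 2

The source may hold more compounds than are shown below. What is called first, only, known or untested is meant among the compounds shown, and "the series" means these compounds.

For the measured compounds named here, in a functional assay on NCI-H460 cells (Homo sapiens) for cytotoxicity, read by sulforhodamine B assay (a lower number here means a stronger inhibitor of growth, a higher number a weaker inhibitor of growth), compound 2 (`CC1=CC[C@@H]([C@@](C)(O)CCCC(C)(C)NC(=S)N/N=C\c2ccccc2[N+](=O)[O-])CC1`) gives 20600 nM and holds the higher of the two numbers so far, while compound 1 (`CC1=CC[C@@H]([C@@](C)(O)CCCC(C)(C)NC(=S)N/N=C\c2ccc(O)cc2)CC1`) gives 1460 nM on the shared core. Compound 3 (`CC1=CC[C@@H]([C@@](C)(O)CCCC(C)(C)NC(=S)N/N=C\c2cccc(Cl)c2)CC1`) has 3-chlorophenyl in place of 2-nitrophenyl on a carbon with a double bond to nitrogen. Going by the values given here, the only measured step at this place is large and beyond the scatter: a 14-fold higher number from compound 1 to compound 2 (1.15 log units; beyond the scatter) on leaving 4-hydroxyphenyl for 2-nitrophenyl. That step shows this place can move the number strongly, and a moderate move back towards compound 1 is expected, with a 4.1-fold lower number from compound 2 to compound 3 (0.61 log units; beyond the scatter) as the estimated step. For compound 3 the estimated value is 5000 nM with an expected range from 1500 nM to 17000 nM in this measurement.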

Compound 3, concentration for 50% growth inhibition: 44300 nM
For compound 3 the middle estimate is 8.9-fold (0.95 log units) below the measured one, outside the stated range (above it).
By their numbers in this assay, from the lowest: compound 1; then compound 2; then compound 3.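

In this assay, 3-chlorophenyl in place of 2-nitrophenyl gives a 2.2-fold higher number from compound 2 to compound 3 (0.33 log units; beyond the scatter), so this second change away from 4-hydroxyphenyl also leaves the number higher. For the compounds shown here, measured against 4-hydroxyphenyl, the change gives a 30-fold higher number from compound 1 to compound 3 (1.48 log units; beyond the scatter), the largest step at this position so far, and 4-hydroxyphenyl remains the group with the lowest number among the three. No supporting evidence bears on why these groups differ. From the compounds shown here alone, how a 4-aminophenyl or 4-carboxyphenyl group would read at this place remains open, as does whether the hydroxyl or its ring location matters for compound 1.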